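A Fluorine Swap on a Benzyl Series Stuck at the Limit

A few compounds are considered here, and "the series" means these few. Any claim that something is new, unique, unknown or untested is made for them only; others in the source may bear on it.

Compound 1 `O=c1ccoc2cc(OCc3cn(Cc4ccccc4)nn3)ccc12`: > 100000 nM
Compound 2 `O=c1ccoc2cc(OCc3cn(Cc4cccc(Br)c4)nn3)ccc12`: > 100000 nM
Compound 3 `O=c1ccoc2cc(OCc3cn(Cc4ccc(Cl)cc4Cl)nn3)ccc12`: > 100000 nM

In a functional assay on MDA-MB-231 cells (Homo sapiens) for cytotoxicity, read by MTT assay, with a stated time of 48 h (on this read-out higher numbers stand for weaker inhibition and lower numbers for stronger inhibition), compound 1 gives > 100000 nM, which is a limit of the assay and not a number. Compound 2 likewise stops at a limit, > 100000 nM. Compound 3 also stops at a limit, > 100000 nM. Because all three values sit at the limit of > 100000 nM in this assay, at which 3 of the 3 values shown sit, the steps a step that the two limits leave unreadable from compound 1 to compound 2, a step that the two limits leave unreadable from compound 1 to compound 3 and a step that the two limits leave unreadable from compound 2 to compound 3 cannot be read in size or direction. Compound 4 `O=c1ccoc2cc(OCc3cn(Cc4ccccc4F)nn3)ccc12` differs from compound 1 by fluoro in place of hydrogen on an aromatic carbon. Going by the values given here, none of the measured changes on the benzyl ring produced a readable number, so compound 4 is expected to remain at the limit as well, the expected step being a step that the limit leaves unreadable from compound 1 to compound 4. The estimate for compound 4 is 150000 nM, within 50000 nM to 500000 nM.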

Compound 4, half-maximal inhibitory concentration: 29800 nM
Compound 4: middle estimate off by 5.0-fold (0.70 log units), on the high side; the whole stated range lies above it.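

In this assay, fluoro in place of hydrogen gives this benzyl series its first readable number, with an at least 3.3-fold lower number from compound 1 to compound 4 (0.52 log units; beyond the scatter). The 2-fluorobenzyl group also separates compound 4 from the two other halogen-bearing compounds, with an at least 3.3-fold lower number from compound 2 to compound 4 (0.52 log units; beyond the scatter) and with an at least 3.3-fold lower number from compound 3 to compound 4 (0.52 log units; beyond the scatter). A single fluoro on this ring is thus enough to leave the limit, whereas the 3-bromophenyl and 2,4-dichlorophenyl groups stay there: the limit of > 100000 nM in this assay, at which 3 of the 4 values shown sit.

From the compounds shown here alone, the true size of each step remains open, as one end of each is a limit. Also open, going by these compounds, is whether a 2-chlorobenzyl or 2-methoxybenzyl group, or fluoro elsewhere on the ring, would give a readable number too.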